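Replacing a phenyl with hydroxy on a sulfonamide piperidine

A few compounds are considered here, and "the series" means these few. Any claim that something is new, unique, unknown or untested is made for them only; others in the source may bear on it.

Compound 1 `Cc1cc(C)c(S(=O)(=O)N2CCC(N3CCC(c4ccccc4)CC3)CC2)c(C)c1` carries a phenyl on a saturated ring carbon. In a functional assay on DLD-1 cells (Homo sapiens) for antiproliferative activity, read by CellTiter-Glo, with a stated time of 72 h (on this read-out lower numbers stand for stronger inhibition and higher numbers for weaker inhibition), compound 1 gives 865 nM, while compound 2 `CC1CCN(C2CCN(S(=O)(=O)c3cccc(-c4ccc(F)cc4)c3)CC2)CC1` gives 12 nM. Of the two numbers shown, compound 1 stands highest, and the gap to compound 2 lies beyond the scatter. Compound 3 `Cc1cc(C)c(S(=O)(=O)N2CCC(N3CCC(O)CC3)CC2)c(C)c1` differs from compound 1 in one place: hydroxy in place of phenyl on a saturated ring carbon. Within the data shown here, no directly comparable step has been measured, so the expectation rests on this change alone. The expected step of a 4.6-fold higher number from compound 1 to compound 3 (0.67 log units; beyond the scatter) points toward weaker inhibition, beyond the scatter. Compound 3 is expected to give 4000 nM, within a range from 1000 nM to 16000 nM.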

Compound 3, half-maximal inhibitory concentration: 106 nM
Compound 3: middle estimate off by 38-fold (1.58 log units), on the high side; measured number outside the range, below it.
By their numbers in this assay, from the lowest: compound 2; then compound 3; then compound 1.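

In this assay the phenyl on this saturated ring carbon proves unnecessary: hydroxy in its place gives an 8.2-fold lower number from compound 1 to compound 3 (0.91 log units; beyond the scatter), a change toward stronger inhibition. A single oxygen atom thus does better here than a six-carbon aromatic ring, so a large aromatic group is not required at this position on the core of compound 1. No available evidence bears on why this happens. On these data alone, whether an amine or a methoxy group on the same ring carbon would match hydroxy remains open, as does whether the hydroxy itself matters or simply the loss of phenyl.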